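Swapping the aryl group on a urea: from nitro to chloro

The source may hold more compounds than are shown below. What is called first, only, known or untested is meant among the compounds shown, and "the series" means these compounds.

Two measured compounds share a core in which a urea links an aromatic ring to a cyclohexane that carries a fluorophenyl ether. Compound 1 `O=C(Nc1cccc(C(F)(F)F)c1)N[C@H]1CC[C@@H](Oc2ccc(F)cc2)CC1` bears a trifluoromethyl group on its aromatic ring; compound 2 `O=C(Nc1ccccc1[N+](=O)[O-])N[C@H]1CC[C@H](Oc2ccc(F)cc2)CC1` bears a nitro group instead. Both were tested in a functional assay on CRL2813 cells (Homo sapiens) for cytotoxicity, read by sulforhodamine B assay, with a stated time of 5 days; on this read-out higher numbers stand for weaker inhibition and lower numbers for stronger inhibition. In this assay compound 1 gives 2600 nM, and compound 2 gives 3500 nM. These two numbers lie within the usual scatter of repeated measurements, so the data do not separate compound 2 from compound 1.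

Compound 3 `O=C(Nc1cccc(Cl)c1)N[C@H]1CC[C@H](Oc2ccc(F)cc2)CC1` has not been measured yet. It differs from compound 2 in one place: 3-chlorophenyl in place of 2-nitrophenyl on an amide-type nitrogen. For the measured compounds named here, with no measured step of this kind among the compounds at hand, there is nothing to suggest a change beyond the scatter in either direction; the expected step from compound 2 to compound 3 is a 1.2-fold lower number from compound 2 to compound 3 (0.07 log units; within the scatter), essentially none. Compound 3 is therefore expected to give about 3000 nM, with a range from 1200 nM to 8000 nM.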

Compound 3, half-maximal inhibitory concentration: 5900 nM
For compound 3 the middle estimate is 2.0-fold (0.29 log units) below the measured one; low and high end bracket the measured number.
By their numbers in this assay, from the lowest: compounds 1, 2 and 3 (each within the scatter of the next, the first and the last beyond it).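

For the compounds shown here, a step of a 1.7-fold higher number from compound 2 to compound 3 (0.23 log units; within the scatter) in this assay is the first measured change of the aromatic group on the amide-type nitrogen. It shows that this assay does not separate 3-chlorophenyl from 2-nitrophenyl at this place, even though a group with hydrogen-bond acceptors gives way to one with none, while the six-membered aromatic ring of carbon stays. Nothing measured here accounts for the size of this step or says what either group does in the cells.

This single swap changes both the substituent and its printed place on the ring, so it cannot show which of the two matters; 2-chlorophenyl and 3-nitrophenyl on the same nitrogen would pull these apart. Also open, from the compounds shown here alone, is how this assay would read for a ring carrying an amine or a carboxylic acid, or for a plain alkyl chain in place of the aromatic ring.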